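This account rests on a few compounds, and the source may have more. Where it says the series, first, only, none or still open, it means among the compounds named here.

In a functional assay on Gurav cells (Homo sapiens) for inhibition, read by sulforhodamine B assay (a lower number here means a stronger inhibitor of growth, a higher number a weaker inhibitor of growth), compound 1 (`COc1ccc(-c2ccc(-c3ccc(-c4nc5ccccc5[nH]4)cc3)cc2)cc1`) gives 38100 nM, compound 2 (`Oc1cccc2[nH]c(-c3ccc(-c4ccc(-c5ccc(F)cc5)cc4)cc3)nc12`) gives 2860 nM and compound 3 (`Oc1cccc2[nH]c(-c3ccc(-c4ccc(-c5ccc(C(F)(F)F)cc5)cc4)cc3)nc12`) gives 3190 nM. Compound 3 therefore lies within the scatter of compound 2 and well below compound 1. Compound 4 (`COc1ccc(-c2ccc(-c3ccc(-c4nc5c(O)cccc5[nH]4)cc3)cc2)cc1`) differs from compound 3 in one place: methoxy in place of trifluoromethyl on an aromatic carbon. Among the measured compounds shown here, the one measured step at this place is a 1.1-fold higher number from compound 2 to compound 3 (0.05 log units; within the scatter), and it stays within the scatter. Compound 1 also carries the methoxy, but its core lacks the hydroxyl group of compound 4, so the value of compound 1, 38100 nM, cannot be credited to methoxy alone. It is still a reason to leave more room towards higher numbers. No step beyond the scatter is therefore expected in this assay, and the estimated change is a 1.3-fold higher number from compound 3 to compound 4 (0.10 log units; within the scatter). For compound 4 the estimated value is 4000 nM, with an expected range from 1600 nM to 12000 nM.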

Compound 4, concentration for 50% growth inhibition: 6630 nM
Beside the measured number, compound 4's estimate is 1.7-fold (0.22 log units) below it, within the range that was stated.
By their numbers in this assay, from the lowest: compounds 2 and 3 (each within the scatter of the next); then compound 4; then compound 1.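

In this assay, this position had so far shown no step beyond the scatter, since fluoro and trifluoromethyl gave values within it, but methoxy now moves the number past it, with a 2.1-fold higher number from compound 3 to compound 4 (0.32 log units; beyond the scatter) and a 2.3-fold higher number from compound 2 to compound 4 (0.37 log units; beyond the scatter), both modest. With the methoxy held fixed, the hydroxy in place of hydrogen on the core gives a 5.7-fold lower number from compound 1 to compound 4 (0.76 log units; beyond the scatter). Nothing measured here says why either change has this effect.

As far as these compounds go, whether the hydroxy step is the same size with fluoro or trifluoromethyl at this position stays open. So does how an amine or a carboxylic acid in the same place would read.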